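A few compounds are considered here, and "the series" means these few. Any claim that something is new, unique, unknown or untested is made for them only; others in the source may bear on it.

The shared core is carried by three measured compounds. Compound 1 `CC/C(=C(/c1ccc(NC(=O)C(C)C)cc1)c1ccc(OC)cc1)c1ccccc1` reaches only a limit in a functional assay on MCF7 cells (Homo sapiens) for inhibition, read by trypan blue exclusion, with a stated time of 72 h (on this read-out lower numbers stand for stronger inhibition of growth and higher numbers for weaker inhibition of growth), namely > 30000 nM. Compound 2 `CC/C(=C(\c1ccccc1)c1ccc(NC(=O)C(C)C)cc1)c1ccc(OCc2ccccc2)cc1` likewise gives only a limit, > 30000 nM. Compound 3 `CC/C(=C(/c1ccc(NC(=O)C(C)C)cc1)c1ccc(OC)cc1)c1ccc(OCc2ccccc2)cc1` gives 29000 nM in this assay. Among the measured compounds shown here, that is the sole number in the set; the other two values sit at the limit of > 30000 nM in this assay, at which 2 of the 3 values shown sit. Two steps lead into compound 3: an at least 1.0-fold lower number from compound 1 to compound 3 (0.01 log units; that floor lies within the scatter), and an at least 1.0-fold lower number from compound 2 to compound 3 (0.01 log units; that floor lies within the scatter). Both rest on the floor set by a limit and lie within the scatter, so neither shows a change that can be trusted.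

Compound 4 `CC/C(=C(/c1ccc(NC(=O)C(C)C)cc1)c1ccc(OC)cc1)c1ccc(O)cc1` is not yet measured. It differs from compound 3 by hydrogen in place of benzyl on an oxygen on an aromatic ring. Neither measured step bears on this change: both add a group where hydrogen stood, whereas here the benzyl is removed from the oxygen, so no size of step can be read from them. With compound 3 sitting close to the limit, a number rather than a limit is expected for compound 4, and the expected step is a 2.9-fold lower number from compound 3 to compound 4 (0.46 log units; beyond the scatter). The estimate for compound 4 in this assay is 10000 nM, with a range from 2000 nM to 40000 nM.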

Compound 4, concentration for 50% growth inhibition: 13600 nM
Beside the measured number, compound 4's estimate is 1.4-fold (0.13 log units) below it; the measured number falls inside the stated range.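

In this assay, among the compounds shown here, removing benzyl from the oxygen gives the first change that can be trusted: a 2.1-fold lower number from compound 3 to compound 4 (0.33 log units; beyond the scatter). The benzyl group is therefore not needed for the growth inhibition seen with compound 3, and the smaller hydroxy group at this place retains a measurable number. Set against the core of compound 1, hydroxy gives an at least 2.2-fold lower number from compound 1 to compound 4 (0.34 log units; beyond the scatter), whereas benzyloxy gives only an at least 1.0-fold lower number from compound 1 to compound 3 (0.01 log units; that floor lies within the scatter); the first of these steps is a floor and not a true size, because compound 1 gives only a limit: the limit of > 30000 nM in this assay, at which 2 of the 4 values shown sit.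

As far as these compounds go, whether the gain depends on the free hydroxy or simply on the loss of benzyl stays open, and an ethoxy group, an amine or a carboxylic acid on the same aromatic carbon would separate those two readings. Also open, from the compounds shown here alone, is whether hydroxy in place of benzyloxy gives a similar step on the core of compound 2, which carries no methoxy group.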